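A Shared Methyl Step Across Two Ester Cores

The compounds below may be only part of what the source reports. "The series", "measured", "known", "first", "only" and "open" are said of these compounds alone.

Of the compounds shown here, three have been tested so far. Compound 1 `COC(=O)C1=C(C)NC(C)=C(C(=O)OC2CCCC2)C1c1csc(-c2ccc(Cl)cc2)n1` gives 7290 nM in an assay on isolated protein for antagonist activity at Voltage-dependent L-type calcium channel subunit alpha-1C (Cavia porcellus), with a stated time of 15 min; a lower number here means a stronger inhibitor, a higher number a weaker inhibitor. Compound 2 `CCOC(=O)C1=C(C)NC(C)=C(C(=O)OC2CCCC2)C1c1csc(-c2ccc(Cl)cc2)n1` gives 8380 nM in this assay, and compound 3 `COC(=O)C1=C(C)NC(C)=C(C(=O)OC(C)c2ccccc2)C1c1csc(-c2ccc(Cl)cc2)n1` gives 7620 nM in this assay. The step of a 1.1-fold higher number from compound 1 to compound 2 (0.06 log units; within the scatter) arises from the change (methyl in place of hydrogen on a saturated chain carbon bound to an oxygen next to a carbonyl group). The step of a 1.0-fold higher number from compound 1 to compound 3 (0.02 log units; within the scatter) arises from the change (1-phenylethyl in place of cyclopentyl on an oxygen next to a carbonyl group). Compound 4 `CCOC(=O)C1=C(C)NC(C)=C(C(=O)OC(C)c2ccccc2)C1c1csc(-c2ccc(Cl)cc2)n1` has not yet been measured. It differs from compound 3 by methyl in place of hydrogen on a saturated chain carbon bound to an oxygen next to a carbonyl group, which is the same kind of change as that from compound 1 to compound 2, made here on a core that differs in the way just described between compound 1 and compound 3. Compound 4 is expected to show a step of a 1.1-fold higher number from compound 3 to compound 4 (0.03 log units; within the scatter) because the same change produced a 1.1-fold higher number from compound 1 to compound 2 (0.06 log units; within the scatter) on the other core. Compound 4 is therefore estimated at 8200 nM in this assay, with a likely range from 4100 nM to 16400 nM.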

Compound 4, half-maximal inhibitory concentration: 13800 nM
The estimate for compound 4 lay 1.7-fold (0.23 log units) below the measured number, and the stated range covers the measured number.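

On the core of compound 3, the methyl change gives a 1.8-fold higher number from compound 3 to compound 4 (0.26 log units; within the scatter), and the swap of cyclopentyl for 1-phenylethyl on the core of compound 2 gives a 1.6-fold higher number from compound 2 to compound 4 (0.22 log units; within the scatter). In this assay, the methyl change reads alike on its two cores: the same change on two cores in this assay, a 1.1-fold higher number (0.06 log units; within the scatter) from compound 1 to compound 2 and a 1.8-fold higher number (0.26 log units; within the scatter) from compound 3 to compound 4, 1.6-fold (0.20 log units) apart, within the scatter of two such steps The 1-phenylethyl change also reads alike, but since all four steps lie within the scatter, this shows only that neither change has a measurable effect on these cores, not that a real effect would carry from one core to another: the same change on two cores in this assay, a 1.0-fold higher number (0.02 log units; within the scatter) from compound 1 to compound 3 and a 1.6-fold higher number (0.22 log units; within the scatter) from compound 2 to compound 4, 1.6-fold (0.20 log units) apart, within the scatter of two such steps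

The compounds shown leave open whether a longer chain in place of the ethyl, or an amine in place of the cyclopentyl or 1-phenylethyl, would give a step beyond the scatter.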